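Amide to Hydroxypiperidine at the Chain Terminus

A few compounds are considered here, and "the series" means these few. Any claim that something is new, unique, unknown or untested is made for them only; others in the source may bear on it.

Two compounds of the series carry numbers in a functional assay on LNCaP cells (Homo sapiens) for antiproliferative activity; a higher number here means a weaker inhibitor, a lower number a stronger inhibitor. Compound 1, `Cn1ncc(Cl)c1-c1cc(C(=O)N[C@@H]2CN[C@H](CC(=O)NC3CC3)C[C@H]2c2ccc(Cl)c(Cl)c2)oc1Cl`, gives 190 nM in this assay. Compound 2, `CC(=O)NCC[C@@H]1C[C@@H](c2ccc(F)c(F)c2)[C@H](NC(=O)c2cc(-c3c(Cl)cnn3C)c(Cl)o2)CN1`, gives 130 nM in this assay. Of the two numbers compound 1 holds the higher one, but the gap to compound 2 lies within the scatter, so the two stand together rather than apart.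

Compound 3, `Cn1ncc(Cl)c1-c1cc(C(=O)N[C@@H]2CN[C@H](CCN3CCC(O)CC3)C[C@H]2c2ccc(Cl)c(Cl)c2)oc1Cl`, is not yet measured. It differs from compound 1 in one place: (4-hydroxypiperidin-1-yl)methyl in place of cyclopropylcarbamoyl on a saturated chain carbon bound to a saturated ring carbon. The substituent on the saturated chain carbon bound to a saturated ring carbon changes from an amide bearing a three-membered ring to a six-membered ring with one hetero atom and a hydroxyl; one donor remains, one acceptor is added.

Within the data shown here, no step between measured compounds informs on this change, and the two numbers so far lie within the scatter of each other. A small step is expected from compound 1 to compound 3 in this assay, a 1.4-fold lower number from compound 1 to compound 3 (0.13 log units; within the scatter), in the direction of a lower number but not clearly beyond the scatter. For compound 3 the estimate in this assay is 140 nM, with a range from 50 nM to 450 nM.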

Compound 3, half-maximal inhibitory concentration: 1140 nM
The estimate for compound 3 lay 8.1-fold (0.91 log units) below the measured number; the measured number lies above the stated range.
By their numbers in this assay, from the lowest: compounds 2 and 1 (each within the scatter of the next); then compound 3.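

This position, on a saturated chain carbon bound to a saturated ring carbon, gives the first reading from a pair differing in one place: in this assay, (4-hydroxypiperidin-1-yl)methyl in place of cyclopropylcarbamoyl gives a 6.0-fold higher number from compound 1 to compound 3 (0.78 log units; beyond the scatter). Among these compounds, the position therefore does not accept every terminus equally, and a basis for comparison now exists where the earlier compounds offered none. The hydrogen-bond donor count is the same on both sides of the change, while the amide carbonyl and the three-membered ring leave and a six-membered ring with a hydroxyl enters, but no measurement here bears on why the number rises.

The shown compounds leave open which part of the change carries the step, since cut one bond further out it reads (cyclopropylcarbamoyl)methyl to 2-(4-hydroxypiperidin-1-yl)ethyl, so the terminus and the link to it change together. An unsubstituted piperidine on the same chain, or a 4-hydroxypiperidine joined through an amide carbonyl, would separate the hydroxyl, the ring and the loss of the amide from one another.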